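Phenyl for benzyl on the ring nitrogen: expected cytotoxicity

A few compounds are considered here, and "the series" means these few. Any claim that something is new, unique, unknown or untested is made for them only; others in the source may bear on it.

Measured so far:
compound 1 `Cc1ccc(NC(=O)c2cccc(/C=C3\CC(=O)N(c4ccccc4)C3=O)c2)cc1` gives > 100000 nM.
compound 2 `CCCCCN1C(=O)C/C(=C\c2cccc(C(=O)Nc3ccc(C)cc3)c2)C1=O` gives > 100000 nM.
compound 3 `CCc1cccc(NC(=O)c2cccc(/C=C3\CC(=O)N(Cc4ccccc4)C3=O)c2)c1` gives > 100000 nM.

Each of these values is a limit of an ADME assay on NCM460 cells (Homo sapiens) for cytotoxicity, read by MTT assay, with a stated time of 72 h (a lower number here means a stronger inhibitor, a higher number a weaker inhibitor), and not a number. Compound 3 therefore stands where the limit of > 100000 nM in this assay, at which 3 of the 3 values shown sit, places every measured compound, with no reading of its own. Compound 4 `CCc1cccc(NC(=O)c2cccc(/C=C3\CC(=O)N(c4ccccc4)C3=O)c2)c1` differs from compound 3 by phenyl in place of benzyl on an amide-type nitrogen in a ring. For the measured compounds named here, the only measured step at that nitrogen, a step that the two limits leave unreadable from compound 1 to compound 2, runs between two limits and shows no size. Compound 1 also carries a phenyl on that nitrogen and gives > 100000 nM, again a limit. Nothing measured points to a readable change, so the step expected in this assay is a number no higher from compound 3 to compound 4 (the limit leaves the size open), within the scatter. For compound 4 the estimated value is 100000 nM, with a range from 40000 nM to 300000 nM.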

Compound 4, half-maximal inhibitory concentration: > 100000 nM
Compound 4: no number, only a limit; the forecaster's own chance of this, stated with the estimate: 85%; the middle value lies on the limit itself.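

Compound 4 gives only a limit, so no step to it from compound 1 or compound 3 can be read, because all these values are limits and not numbers in this assay: the limit of > 100000 nM in this assay, at which 4 of the 4 values shown sit.

The compounds shown leave open at what concentration any of them reaches half-maximal inhibition, and so whether phenyl or benzyl on the amide-type nitrogen in a ring makes any difference.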